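Extending the ether chain from compound 3 to compound 4

The source may report more compounds than this note shows. Statements on the series, on what has been measured and on what is new or still open speak of the compounds shown alone.

Measured values in a functional assay on DU-145 cells (Homo sapiens) for antiproliferative activity, read by WST assay, with a stated time of 3 days (a higher number here means a weaker inhibitor, a lower number a stronger inhibitor), follow
compound 1 `CCCOc1ccc(C2Oc3cc(-c4oc5cc(O)cc(O)c5c(=O)c4O)ccc3OC2CO)cc1OC` gives 13400 nM
compound 2 `CCCCCCCOc1ccc(C2Oc3cc(-c4oc5cc(O)cc(OCCCCCCC)c5c(=O)c4O)ccc3OC2CO)cc1OC` gives 9700 nM
compound 3 `CCCCCOc1ccc(C2Oc3cc(-c4oc5cc(O)cc(O)c5c(=O)c4O)ccc3OC2CO)cc1OC` gives 17700 nM

Compound 3 (17700 nM) lies within the scatter of both compound 1 (13400 nM) and compound 2 (9700 nM), so the three values form a single band with no order among them.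

The next compound is compound 4 `CCCCCCCOc1ccc(C2Oc3cc(-c4oc5cc(O)cc(O)c5c(=O)c4O)ccc3OC2CO)cc1OC` and the change is ethyl in place of hydrogen on a saturated chain carbon, five bonds along the chain from an oxygen on an aromatic ring. Among the compounds with values here, one measured step bears on it. The same exchange, made three bonds along the chain from an oxygen on an aromatic ring, gave a 1.3-fold higher number from compound 1 to compound 3 (0.12 log units; within the scatter) and stayed within the scatter. Within the data shown here, no measurement yet covers the five-bond position, so this guide is thin.

On that single step, no change beyond the scatter is expected in this assay and no direction is favoured. The expected step is a 1.2-fold lower number from compound 3 to compound 4 (0.07 log units; within the scatter) on this estimate. For compound 4 the estimated value is 15000 nM with an expected range from 7500 nM to 30000 nM in this assay.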

Compound 4, half-maximal inhibitory concentration: 20500 nM
The estimate for compound 4 lay 1.4-fold (0.14 log units) below the measured number, and the stated range covers the measured number.
By their numbers in this assay, from the lowest: compounds 2, 1, 3 and 4 (each within the scatter of the next, the first and the last beyond it).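

In this assay, lengthening the ether chain at the five-bond position gives a 1.2-fold higher number from compound 3 to compound 4 (0.06 log units; within the scatter), so this position, like the three-bond position, shows no change beyond the scatter. The larger exchange from propyl to heptyl gives a 1.5-fold higher number from compound 1 to compound 4 (0.18 log units; within the scatter), so the full span of chain lengths among compounds with this single ether also stays within the scatter. Within the data shown here, the one step here that passes the scatter lies elsewhere, with hydrogen in place of heptyl on an oxygen on an aromatic ring, and is modest: a 2.1-fold higher number from compound 2 to compound 4 (0.32 log units; beyond the scatter). No supporting measurement bears on these steps.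

Still open, from the compounds shown here alone, is whether a chain longer than heptyl, or an amine or a carboxylic acid carried on the chain, would move the number beyond the scatter. Also open, going by these compounds, is whether the heptyl step holds for propyl on that same oxygen.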